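Aryl Substituent Swaps on a Shared Core: Cytotoxicity Outlook

The source may hold more compounds than are shown below. What is called first, only, known or untested is meant among the compounds shown, and "the series" means these compounds.

Compound 1 `Fc1ccc(C2CC(c3ccc(Cl)s3)=NN2c2nc(-c3ccc(Cl)cc3)cs2)cc1` in an ADME assay on NIH3T3 cells (Mus musculus) for cytotoxicity, read by XTT assay, with a stated time of 24 h (a lower number here means a stronger inhibitor, a higher number a weaker inhibitor), gives > 500 ug/mL, which is a limit of the assay.
Compound 2 `Fc1ccc(C2CC(c3ccc(Cl)s3)=NN2c2nc(-c3ccc(C(F)(F)F)cc3)cs2)cc1` in this assay gives > 500 ug/mL, which is a limit of the assay.
Compound 3 `Fc1ccc(C2CC(c3ccc(Cl)s3)=NN2c2nc(-c3ccc(Br)cc3)cs2)cc1` in this assay gives > 500 ug/mL, which is a limit of the assay.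

Compound 3 therefore stands where every measured compound stands: at the limit of > 500 ug/mL in this assay, at which 3 of the 3 values shown sit. The steps a step that the two limits leave unreadable from compound 1 to compound 3, a step that the two limits leave unreadable from compound 2 to compound 3 and a step that the two limits leave unreadable from compound 1 to compound 2 are all unreadable, each of them beginning and ending at that limit, so none of them reveals how a change at this position moves the read-out.

Compound 4 `CS(=O)(=O)c1ccc(-c2csc(N3N=C(c4ccc(Cl)s4)CC3c3ccc(F)cc3)n2)cc1` differs from compound 3 by methylsulfonyl in place of bromo on an aromatic carbon. Since the measured steps bearing on this position are all unreadable, no direction can be taken from them. Compound 4 is expected to remain at the limit, with the step of a number no higher from compound 3 to compound 4 (the limit leaves the size open) expected to be none beyond the scatter. The estimate for compound 4 in this assay is 500 ug/mL, with a range from 300 ug/mL to 1000 ug/mL.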

Compound 4, half-maximal inhibitory concentration: > 500 ug/mL
Compound 4 was reported as a limit; the forecaster's own chance of this, stated with the estimate: 85%; the middle value sits exactly at the limit.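

The steps from compound 1, compound 2 and compound 3 to compound 4 cannot be read, since all four compounds sit at one limit: the limit of > 500 ug/mL in this assay, at which 4 of the 4 values shown sit.

The compounds shown leave open whether any of these substituents changes the half-maximal inhibitory concentration in this assay at all.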